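MCH receptor 1 series: amine at the quinoline nitrogen position

The source may report more compounds than this note shows. Statements on the series, on what has been measured and on what is new or still open speak of the compounds shown alone.

Measured compounds:
compound 1 `O=C(CCc1ccc(C(F)(F)F)cc1)Nc1ccc2nc(N3CCCCCC3)ccc2c1`: 1800 nM
compound 2 `CNC(=O)NC1CCN(c2ccc3cc(NC(=O)CCc4ccc(C(F)(F)F)cc4)ccc3n2)C1`: 30 nM

In a functional assay on HEK293 cells for activation of melanin-concentrating hormone receptor 1 (Rattus norvegicus), read by inositol phosphate accumulation (on this read-out higher numbers stand for an effect only at larger amounts of compound and lower numbers for an effect already at smaller amounts), compound 2 gives the lowest number of the two; compound 1 gives a higher number, a 60-fold lower number from compound 1 to compound 2 (1.78 log units; beyond the scatter) separating them. Compound 3 `O=C(CCc1ccc(C(F)(F)F)cc1)Nc1ccc2nc(N3CC4CCC3C4)ccc2c1` differs from compound 2 by a group of 7 heavy atoms (6 carbon, 1 nitrogen; one five-membered non-aromatic ring of carbon only, one five-membered non-aromatic ring with 1 hetero atom) in place of a group of 10 heavy atoms (6 carbon, 3 nitrogen, 1 oxygen; one five-membered non-aromatic ring with 1 hetero atom), on an aromatic carbon. For the measured compounds named here, the only step that bears on this change is the one from compound 1 to compound 2, where removing the azepanyl group and introducing the urea-bearing pyrrolidinyl group produced that large lowering. Compound 3 carries an amine with no hydrogen-bond donor, closer to compound 1 in that respect, so a rise in the number is expected, a 30-fold higher number from compound 2 to compound 3 (1.48 log units; beyond the scatter). For compound 3 the estimate is 900 nM, range 200 nM to 4000 nM.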

Compound 3, half-maximal effective concentration: 150 nM
Estimate against measurement, compound 3: 6.0-fold (0.78 log units) above, and the stated range ends above it.
By their numbers in this assay, from the lowest: compound 2; then compound 3; then compound 1.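

With 0 hydrogen-bond donors in the entering group, the amine at this position still gives a 12-fold lower number from compound 1 to compound 3 (1.08 log units; beyond the scatter), so a large drop from the azepan-1-yl level does not depend on the 3-((methylcarbamoyl)amino)pyrrolidin-1-yl group. That group nevertheless keeps a modest edge, seen as a 5.0-fold higher number from compound 2 to compound 3 (0.70 log units; beyond the scatter). Nothing available gives a cause for either step. Still open, from the compounds shown here alone, is where a plain pyrrolidin-1-yl group, carrying neither the urea nor a second ring, would fall relative to these numbers, and whether a simple amine on the pyrrolidine could stand in for the urea.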